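Replacing the hydroxy(phenyl)methyl group in compound 2

The source may report more compounds than this note shows. Statements on the series, on what has been measured and on what is new or still open speak of the compounds shown alone.

Values so far in an in vitro ADME assay on microsomes from liver (Homo sapiens) for metabolic stability (a lower number here means that the compound disappears faster, a higher number that the compound lasts longer), are as follows.
compound 1 `CC(C)CC1n2cncc2CN(CC2CC2)S1(=O)=O` at 0.917 h
compound 2 `C[C@@H](c1ccc(Cl)cc1)N1Cc2cncn2C(C[C@@H](O)c2ccccc2)S1(=O)=O` at 0.4 h

Of the two, compound 2 stands lowest at 0.4 h, and compound 1 lies above it by more than the usual scatter. The next compound to be read is compound 3 `COC(C)(C)CC1n2cncc2CN([C@@H](C)c2ccc(Cl)cc2)S1(=O)=O`, in which 1-methoxy-1-methylethyl stands in place of hydroxy(phenyl)methyl on a saturated chain carbon bound to a saturated ring carbon (1-methoxy-1-methylethyl in place of hydroxy(phenyl)methyl on a saturated chain carbon bound to a saturated ring carbon). Among the measured compounds shown here, no two measured compounds differ in one place only, so this change has no direct precedent. For the measured compounds named here, the only guide is compound 1 at 0.917 h, which also has no phenyl ring on that chain, and this is weak support from a single compound. In this assay the expected step is upward and modest (a 1.8-fold higher number from compound 2 to compound 3 (0.24 log units; within the scatter)), close to the scatter and possibly not beyond it. For compound 3 the estimated half-life is 0.7 h (expected range 0.35 h to 1.4 h).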

Compound 3, half-life: 0.2 h
For compound 3 the middle estimate is 3.5-fold (0.54 log units) above the measured one; measured number below the stated range.
By their numbers in this assay, from the lowest: compounds 3 and 2 (each within the scatter of the next); then compound 1.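

In this assay, among the compounds shown here, the first direct reading at this place, on a saturated chain carbon bound to a saturated ring carbon, is 1-methoxy-1-methylethyl in place of hydroxy(phenyl)methyl, which gives a 2.0-fold lower number from compound 2 to compound 3 (0.30 log units; within the scatter). This change removes the six-membered aromatic ring, the hydrogen-bond donor and the defined stereocentre of the leaving group together, yet the step does not go beyond the scatter, so dropping the phenyl ring from this chain does not by itself give a longer-lasting compound in this pair. No measurement available here bears on what lies behind this result.

Compound 1 differs from compound 3 in more than one place, so its position in the series cannot be tied to the chain alone, and the contributions of the hydroxy group, the phenyl ring and the methoxy group remain unseparated. Also open, as far as these compounds go, is whether a carboxylic acid or an amine at the end of this chain, or a longer chain, would move the half-life beyond the scatter.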